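The compounds below may be only part of what the source reports. "The series", "measured", "known", "first", "only" and "open" are said of these compounds alone.

Measured compounds:
compound 1, `Cc1nn(-c2ncnc3nc[nH]c23)c2c1C(OCC(=O)c1ccc(F)cc1)CC(=O)N2`: 3 nM
compound 2, `CCCCCCCCOC1CC(=O)Nc2c1c(C)nn2-c1ncnc2nc[nH]c12`: 8 nM
compound 3, `Cc1nn(-c2ncnc3nc[nH]c23)c2c1C(OCCn1cccn1)CC(=O)N2`: 16 nM

In a functional assay on HEK293 cells for agonist activity at G-protein coupled receptor 39 (Homo sapiens), read by scintillation proximity assay and inositol phosphate accumulation, with a stated time of 75 min, in the presence of a further agent that is not named here (on this read-out higher numbers stand for an effect only at larger amounts of compound and lower numbers for an effect already at smaller amounts), compound 3 gives 16 nM, the highest of the three numbers. Its nearest neighbour is compound 2 with 8 nM, and a 2.0-fold higher number from compound 2 to compound 3 (0.30 log units; within the scatter) lies within the scatter. Compound 1 gives 3 nM, and a 5.3-fold higher number from compound 1 to compound 3 (0.73 log units; beyond the scatter) is a modest step beyond the scatter.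

Compound 4, `Cc1nn(-c2ncnc3nc[nH]c23)c2c1C(OCc1ccccc1Cl)CC(=O)N2`, has not been measured. Its difference from compound 3 is 2-chlorophenyl in place of (1H-pyrazol-1-yl)methyl on a saturated chain carbon bound to an oxygen on a saturated carbon. For the measured compounds named here, the steps that bear on this change are those leading into compound 3: a 5.3-fold higher number from compound 1 to compound 3 (0.73 log units; beyond the scatter), where a (4-fluorophenyl)carbonyl on the same chain carbon gives a clearly lower number, and a 2.0-fold higher number from compound 2 to compound 3 (0.30 log units; within the scatter), where a hexyl two bonds along the chain does not separate from the pyrazole beyond the scatter. An aromatic carbon ring in place of the pyrazole is therefore expected to move the number back down, though not by the whole span seen for compound 1. The estimate for compound 4 is a step of a 2.0-fold lower number from compound 3 to compound 4 (0.30 log units; within the scatter) in this assay, giving an expected value of 8 nM, with a range from 3 nM to 25 nM.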

Compound 4, half-maximal effective concentration: 2 nM
Compound 4: the middle estimate sits 4.0-fold (0.60 log units) above what was measured; measured number below the stated range.
By their numbers in this assay, from the lowest: compounds 4 and 1 (each within the scatter of the next); then compounds 2 and 3 (each within the scatter of the next).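

In this assay, for the compounds shown here, 2-chlorophenyl in place of (1H-pyrazol-1-yl)methyl on this saturated chain carbon gives an 8.0-fold lower number from compound 3 to compound 4 (0.90 log units; beyond the scatter) and so separates clearly from the pyrazole, a result the earlier compounds could only approach through a different side chain. The same group also gives a 4.0-fold lower number from compound 2 to compound 4 (0.60 log units; beyond the scatter) and so stands clear of the heptyl chain, whereas it stays level with the (4-fluorophenyl)carbonyl side chain, with a 1.5-fold lower number from compound 1 to compound 4 (0.18 log units; within the scatter) inside the scatter, which shows that among these compounds a low number at this position does not depend on a carbonyl in the side chain. Nothing given here accounts for why these changes act as they do.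

The compounds shown leave open what the chlorine itself contributes, as none of them carries a plain benzyl group or a 2-chlorobenzyl isomer with the chlorine elsewhere on the ring. 2-(1H-pyrazol-1-yl)ethyl and 2-chlorobenzyl differ in both ring and chain. A 2-phenylethyl group, or a benzyl group bearing an amine or a carboxylic acid, would be needed to show which of these matters and how much else this position tolerates.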